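The compounds below may be only part of what the source reports. "The series", "measured", "known", "first", "only" and "open" are said of these compounds alone.

Of the compounds shown here, three that share one core have been measured in a functional assay on A549 cells (Homo sapiens) for inhibition, read by MTT assay, with a stated time of 24 h; a higher number here means a weaker inhibitor, a lower number a stronger inhibitor. Compound 1 `CCOC(=O)C1=Cc2ccccc2OC1(OCc1cn(-c2ccc(F)cc2)nn1)C(F)(F)F` gives 7300 nM in this assay, and compound 2 `CCOC(=O)C1=Cc2ccccc2OC1(OCc1cn(-c2ccc(F)c([N+](=O)[O-])c2)nn1)C(F)(F)F` gives 11900 nM; the step of a 1.6-fold higher number from compound 1 to compound 2 (0.21 log units; within the scatter) changes little. Compound 3 `CCOC(=O)C1=Cc2ccccc2OC1(OCc1cn(-c2ccc([N+](=O)[O-])cc2)nn1)C(F)(F)F` stands apart: in this assay compound 3 reaches only the limit > 150000 nM, which is a limit of the measurement and not a number (the limit of > 150000 nM in this assay, at which 1 of the 3 values shown sits). Among the compounds with values here, the step of an at least 20-fold higher number from compound 1 to compound 3 (1.31 log units; beyond the scatter) and the step of an at least 12-fold higher number from compound 2 to compound 3 (1.10 log units; beyond the scatter) both lie well beyond the scatter, and both end at compound 3, the one member carrying a nitro group with nothing else on that ring. Compound 4 `CCOC(=O)C1=Cc2ccccc2OC1(OCc1cn(-c2ccc(C)cc2)nn1)C(F)(F)F` has not yet been measured. It differs from compound 3 by methyl in place of nitro on an aromatic carbon. Against the step of an at least 20-fold higher number from compound 1 to compound 3 (1.31 log units; beyond the scatter), the change to compound 4 is expected to run the other way, as a step of an at least 18-fold lower number from compound 3 to compound 4 (1.27 log units; beyond the scatter) in this assay. Compound 4 is therefore estimated at 8000 nM, with a range from 2000 nM to 40000 nM.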

Compound 4, half-maximal inhibitory concentration: 19700 nM
Estimate against measurement, compound 4: 2.5-fold (0.39 log units) below; the range from low to high includes it.
By their numbers in this assay, from the lowest: compounds 1, 2 and 4 (each within the scatter of the next, the first and the last beyond it). At a limit, above all of these: compound 3.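

In this assay, methyl in place of nitro on this aromatic carbon, para to a large group, gives an at least 7.6-fold lower number from compound 3 to compound 4 (0.88 log units; beyond the scatter), so the position is not closed to every group other than fluoro. Methyl does not fully match fluoro here, with a 2.7-fold higher number from compound 1 to compound 4 (0.43 log units; beyond the scatter), while a 1.7-fold higher number from compound 2 to compound 4 (0.22 log units; within the scatter) sets no order between those two compounds. Compound 3 itself stands at a limit of the measurement and not at a number: the limit of > 150000 nM in this assay, at which 1 of the 4 values shown sits.

The compounds shown place only fluoro, methyl and nitro on this carbon, so they leave open how an amine, a methoxy group or a carboxylic acid there would read. They also cannot say why compound 3 reaches a limit while compound 2, which also carries a nitro group, does not.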